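The compounds below may be only part of what the source reports. "The series", "measured", "known", "first", "only" and "open" are said of these compounds alone.

Working notes on the series, read in an ADME assay on MRC5 cells (Homo sapiens), read by MTT assay, with a stated time of 72 h; on this read-out lower numbers stand for stronger inhibition and higher numbers for weaker inhibition. Compound 1 `COc1ncnc2c1c(-c1ccccc1)cn2[C@@H]1O[C@H](CO)[C@@H](O)[C@H]1O` gives > 100000 nM, which is a limit and not a number. Among the compounds with values here, compound 2 `COc1ncnc2c1c(-c1cc3ccccc3o1)cn2[C@@H]1O[C@H](CO)[C@@H](O)[C@H]1O` gives 65600 nM, the only actual number so far. The next change, from compound 2 to compound 3 `C#Cc1cn([C@@H]2O[C@H](CO)[C@@H](O)[C@H]2O)c2ncnc(OC)c12`, puts ethynyl in place of 1-benzofuran-2-yl on an aromatic carbon. Within the data shown here, the one measured step bearing on this position is an at least 1.5-fold lower number from compound 1 to compound 2 (0.18 log units; that floor lies within the scatter), with 1-benzofuran-2-yl in place of phenyl. As far as these compounds go, compound 1 rests on (the limit of > 100000 nM in this assay, at which 1 of the 2 values shown sits), so the true size of that step stays open. Among the measured compounds shown here, no measured step covers ethynyl, so no shift beyond the scatter is expected in this assay. The expected step is a 1.3-fold lower number from compound 2 to compound 3 (0.12 log units; within the scatter). Compound 3 is estimated at 50000 nM, with an expected range of 8000 nM to 100000 nM.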

Compound 3, half-maximal inhibitory concentration: > 100000 nM
Compound 3 was reported as a limit; the forecaster's own chance of this, stated with the estimate: 40%; middle value at least 2.0-fold (0.30 log units) from the limit.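

In this assay, the change to ethynyl on this aromatic carbon gives an at least 1.5-fold higher number from compound 2 to compound 3 (0.18 log units; that floor lies within the scatter), so a group much smaller than 1-benzofuran-2-yl has not yet been shown to change the read-out beyond the scatter. Compound 1 and compound 3 both stand at the limit, so the step between them cannot be read, and phenyl and ethynyl cannot be ranked against each other. Compound 2 remains the only one of the three with an actual number, and the rest of the series sits at the assay's ceiling: the limit of > 100000 nM in this assay, at which 2 of the 3 values shown sit.

As far as these compounds go, how far the true values of compound 1 and compound 3 lie from that of compound 2 stays open. Also open, from the compounds shown here alone, is whether an amine, a carboxylic acid or a longer carbon chain on this aromatic carbon would give a number that can be read.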